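The source may report more compounds than this note shows. Statements on the series, on what has been measured and on what is new or still open speak of the compounds shown alone.

Compound 1 `COC(=O)c1nc(C)n(-c2ccc(C(F)(F)F)cc2)n1` and compound 2 `COC(=O)c1nc(C2CCCCC2)n(-c2ccc(C(F)(F)F)cc2)n1` share a core that carries a methoxycarbonyl group and a 4-(trifluoromethyl)phenyl group, and differ only in the group on one aromatic carbon of that core. In a functional assay on NPC-TW01 cells (Homo sapiens) for inhibition, read by MTT assay, with a stated time of 72 h (on this read-out higher numbers stand for weaker inhibition of growth and lower numbers for stronger inhibition of growth), compound 1 gives > 100000 nM, which is a limit of the measurement and not a number. In this assay compound 2 likewise gives > 100000 nM, again a limit and not a number. The step that the two limits leave unreadable from compound 1 to compound 2 therefore cannot be read, as both values sit at the limit of > 100000 nM in this assay, at which 2 of the 2 values shown sit. Compound 2 thus stands at the limit, with no numerical position within the assay.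

Compound 3 `COC(=O)c1nc(-c2ccc[nH]2)n(-c2ccc(C(F)(F)F)cc2)n1` follows from compound 2 by the change (1H-pyrrol-2-yl in place of cyclohexyl on an aromatic carbon). No measured step reaches across this change, and the one step that is shown, from compound 1 to compound 2, is itself unreadable. Among the compounds with values here, nothing among the measured compounds points to growth inhibition appearing with the 1H-pyrrol-2-yl group, so the account expects compound 3 to remain near the limit, with an expected step of a number no higher from compound 2 to compound 3 (the limit leaves the size open). The estimate for compound 3 in this assay is 100000 nM, within a range from 30000 nM to 300000 nM.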

Compound 3, concentration for 50% growth inhibition: > 100000 nM
Compound 3 ended at the assay's limit (the forecaster's own chance of this, stated with the estimate: 80%); the middle value lies on the limit itself.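

In this assay compound 3 gives > 100000 nM which is a limit of the measurement and not a number. Within the data shown here, no step among compound 1, compound 2 and compound 3 can therefore be read, as all three values sit at the same limit: (the limit of > 100000 nM in this assay, at which 3 of the 3 values shown sit). The compounds shown leave open whether any group at this place on the shared core gives a measurable inhibition of growth.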